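Extending the Pentyl Chain with Diethylamino: Cytotoxicity Outlook

The compounds below may be only part of what the source reports. "The series", "measured", "known", "first", "only" and "open" are said of these compounds alone.

Measured so far:
compound 1 `Cc1ccccc1-c1nn(-c2ccc(F)cc2F)cc1CNC1CCN(S(C)(=O)=O)CC1`: > 20000 nM, a limit of the assay
compound 2 `Cc1ccccc1-c1nn(-c2ccc(F)cc2F)cc1CNCc1ccncc1`: > 20000 nM, a limit of the assay
compound 3 `CCCCCNCc1cn(-c2ccc(F)cc2F)nc1-c1ccccc1C`: 17000 nM

In an ADME assay on Huh-7 cells (Homo sapiens) for cytotoxicity (a lower number here means that less compound is tolerated, a higher number that more compound is tolerated), compound 1 gives > 20000 nM, which is a limit of the assay rather than a number. Compound 2 likewise gives > 20000 nM, again a limit. Going by the values given here, compound 3 gives 17000 nM, the only number among the three. The other two values both sit at one point (the limit of > 20000 nM in this assay, at which 2 of the 3 values shown sit). The two readable steps, an at least 1.1-fold lower number from compound 1 to compound 3 (0.07 log units; that floor lies within the scatter) and an at least 1.1-fold lower number from compound 2 to compound 3 (0.07 log units; that floor lies within the scatter), are floors that lie within the scatter, while a step that the two limits leave unreadable from compound 1 to compound 2 cannot be read from two limits.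

Compound 4 `CCN(CC)CCCNCc1cn(-c2ccc(F)cc2F)nc1-c1ccccc1C` differs from compound 3 by diethylamino in place of ethyl on a saturated chain carbon, three bonds along the chain from an amine nitrogen. Both earlier steps into compound 3 also changed the group on the amine nitrogen without a readable effect, so no step beyond the scatter is expected here either. The expected step from compound 3 to compound 4 is no change at the digits printed from compound 3 to compound 4 (within the scatter), and compound 4 is estimated at 17000 nM, between 6000 nM and 40000 nM.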

Compound 4, half-maximal cytotoxic concentration: > 20000 nM
Compound 4 ended at the assay's limit; the forecaster's own chance of this, stated with the estimate: 40%; middle value at least 1.1-fold (0.07 log units) away from the limit.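

In this assay compound 4 gives > 20000 nM, which is a limit of the assay and not a number. Going by these compounds alone, the one readable step is an at least 1.1-fold higher number from compound 3 to compound 4 (0.07 log units; that floor lies within the scatter), so at this place on the chain, diethylamino in place of ethyl shows no lowering of the number, but the true size of the step remains hidden. The steps from compound 1 and compound 2 to compound 4 cannot be read, and a chain ending in diethylamino now sits at the same limit as the methylsulfonyl piperidine and pyridine side groups: the limit of > 20000 nM in this assay, at which 3 of the 4 values shown sit.

Going by these compounds, how much compound 1, compound 2 and compound 4 differ from one another remains open, as none of the three has a number. Also open, on these data alone, is whether a morpholine or a dimethylamino group at the chain end, or a longer chain, would stay at this limit.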